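A phenyl group exchanged: compound 3 to compound 4

The source may hold more compounds than are shown below. What is called first, only, known or untested is meant among the compounds shown, and "the series" means these compounds.

Measured values (a physicochemical assay for solubility, in phosphate buffer, measured as kinetic solubility, at pH 7.4; on this read-out lower numbers stand for lower solubility and higher numbers for higher solubility)
Compound 1 `Cc1oc(-c2c(Br)cccc2Br)nc1CN1CCC(C(=O)NCCCN2C[C@H](C)C[C@H](C)C2)CC1` gives 62.4 ug/mL
Compound 2 `Cc1ccc(-c2nc(CN3CCC(C(=O)NCCCN4C[C@H](C)C[C@H](C)C4)CC3)c(C)o2)cc1` gives > 69 ug/mL (a limit)
Compound 3 `COc1cccc(C)c1-c1nc(CN2CCC(C(=O)NCCCN3C[C@H](C)C[C@H](C)C3)CC2)c(C)o1` gives > 73 ug/mL (a limit)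

For compound 3 the reading > 73 ug/mL is a limit and not a number. Compound 4 `COc1ccc(-c2nc(CN3CCC(C(=O)NCCCN4C[C@H](C)C[C@H](C)C4)CC3)c(C)o2)cc1OC` carries 3,4-dimethoxyphenyl in place of 2-methoxy-6-methylphenyl on an aromatic carbon. Among the compounds with values here, three measured steps bear on this exchange: an at least 1.1-fold higher number from compound 1 to compound 2 (0.04 log units; that floor lies within the scatter) and an at least 1.1-fold higher number from compound 1 to compound 3 (0.06 log units; that floor lies within the scatter) are floors within the scatter, while a step that the two limits leave unreadable from compound 2 to compound 3 gives no readable size. On these steps, no change beyond the scatter is expected in this assay, and the estimated step is a step that the limit leaves unreadable from compound 3 to compound 4 in size. The estimate for compound 4 is 75 ug/mL (expected range 50 ug/mL to 85 ug/mL).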

Compound 4, solubility: > 76 ug/mL
Compound 4: only a limit was reported (the forecaster's own chance of this, stated with the estimate: 75%); at least 1.0-fold (0.00 log units) between middle value and limit.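

Compound 4 gives > 76 ug/mL in this assay and that reading is a limit. This aromatic carbon thus also takes 3,4-dimethoxyphenyl, with its 2 hydrogen-bond acceptors, and the reading again comes out as a limit and not a number. Within the data shown here, the one readable comparison (an at least 1.2-fold higher number from compound 1 to compound 4 (0.08 log units; that floor lies within the scatter)) stays within the scatter, and the steps among compound 2, compound 3 and compound 4 cannot be read.

The compounds shown leave open how far any of these three readings lies beyond its limit. They also leave open whether an amine or a carboxylic acid on the phenyl ring would give a step beyond the scatter.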